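Bromo-methoxy amide expected near its fluoro-iodo parent

The compounds below may be only part of what the source reports. "The series", "measured", "known", "first", "only" and "open" are said of these compounds alone.

Compound 2 `O=C(Nc1ccc(S(=O)(=O)Nc2ccccc2)cc1)c1ccc(I)cc1F` bears a 2-fluoro-4-iodophenyl group on the carbonyl carbon of the shared core. Among the measured compounds shown here, in a functional assay on HEK293 cells for agonist activity at probable G-protein coupled receptor 27 (Homo sapiens), read by a luciferase reporter and beta-arrestin recruitment, with a stated time of 10 min (on this read-out lower numbers stand for an effect already at smaller amounts and higher numbers for an effect only at larger amounts of compound), compound 2 gives 5130 nM, the only numeric value among the three measured compounds. Compound 1 `O=C(Nc1ccc(S(=O)(=O)NCc2ccccc2)cc1)c1ccc(Cl)cc1Cl` gives only a limit of the assay, > 100000 nM. Compound 3 `O=C(Nc1ccc(S(=O)(=O)Nc2ccc(Cl)cc2)cc1)c1ccc(Cl)cc1Cl` likewise gives only a limit, > 100000 nM. The step that the two limits leave unreadable from compound 1 to compound 3 cannot be read, since both ends sit at the limit of > 100000 nM in this assay, at which 2 of the 3 values shown sit. Compound 4 `COc1cc(Br)ccc1C(=O)Nc1ccc(S(=O)(=O)Nc2ccccc2)cc1` differs from compound 2 by 4-bromo-2-methoxyphenyl in place of 2-fluoro-4-iodophenyl on a carbonyl carbon. For the measured compounds named here, no measured step touches the carbonyl side of the molecule, so the measured steps give no guide here. Compound 4 is therefore expected to give 8000 nM, between 2000 nM and 40000 nM, an estimated step of a 1.6-fold higher number from compound 2 to compound 4 (0.19 log units; within the scatter) of no clear direction beyond the scatter.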

Compound 4, half-maximal effective concentration: 1020 nM
The estimate for compound 4 lay 7.8-fold (0.89 log units) above the measured number, outside the stated range (below it).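

Among the compounds shown here, putting 4-bromo-2-methoxyphenyl in place of 2-fluoro-4-iodophenyl on the carbonyl carbon gives a 5.0-fold lower number from compound 2 to compound 4 (0.70 log units; beyond the scatter) as the first readable step at this position. It shows that the number in this assay responds to what sits on the carbonyl carbon, and that the entering group, with its one hydrogen-bond acceptor, is tolerated there. Going by these compounds, both substituents on the ring change at once, so the share of each stays open, as does the outcome with an amine or a carboxylic acid on this ring. Nothing shown here explains the lower number.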